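Isopropyl to tert-Butyl: Expected Stability of Compound 3

A few compounds are considered here, and "the series" means these few. Any claim that something is new, unique, unknown or untested is made for them only; others in the source may bear on it.

Compound 1 `CC(C)C(=O)N/C(=N/c1nccn1C(C)C)Nc1ccc(Cl)c(Cl)c1` gives > 1 h in an in vitro ADME assay on microsomes from liver (Homo sapiens) for metabolic stability, read by LC-MS, tested at 1 uM (on this read-out lower numbers stand for a shorter-lived compound and higher numbers for a longer-lived compound), which is a limit of that assay.
Compound 2 `CC(C)n1ccnc1/N=C(/NC(=O)C(C)(C)C)Nc1ccc(Cl)c(Cl)c1` gives > 1 h in this assay, also a limit.

Compound 2 thus stands at the limit where both values sit (the limit of > 1 h in this assay, at which 2 of the 2 values shown sit). Compound 3 `CC(C)(C)C(=O)N/C(=N/c1nccn1C(C)(C)C)Nc1ccc(Cl)c(Cl)c1` differs from compound 2 by methyl in place of hydrogen on a saturated chain carbon bound to an aromatic nitrogen and two saturated chain carbons. Among the compounds with values here, the only measured step, a step that the two limits leave unreadable from compound 1 to compound 2, is the same kind of change at another place, and its size is unreadable. The expected step that the limit leaves unreadable from compound 2 to compound 3 is therefore none beyond the scatter. Compound 3 is estimated at 1.5 h, between 0.7 h and 4 h, most likely reported again only as a limit.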

Compound 3, half-life: > 1 h
Compound 3 ended at the assay's limit (the forecaster's own chance of this, stated with the estimate: 75%); the middle value does not contradict the limit.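

The step from compound 2 to compound 3 cannot be read, for both values are limits and not numbers: the limit of > 1 h in this assay, at which 3 of the 3 values shown sit.
As far as these compounds go, how long compound 1, compound 2 and compound 3 actually last in this assay and how they compare stay open.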